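The compounds below may be only part of what the source reports. "The series", "measured", "known", "first", "only" and "open" are said of these compounds alone.

- compound 1 `COc1cc(-c2nccn2-c2ccc(C)cc2)cc(OC)c1OC`: 400 nM
- compound 2 `COc1cccc(-n2ccnc2-c2cc(OC)c(OC)c(OC)c2)c1`: 10400 nM
- compound 3 `COc1ccc(-n2ccnc2-c2cc(OC)c(OC)c(OC)c2)cc1`: not yet measured

In a functional assay on MDA-MB-468 cells (Homo sapiens) for antiproliferative activity, read by MTT assay, with a stated time of 72 h (on this read-out lower numbers stand for stronger inhibition and higher numbers for weaker inhibition), compound 2 has the higher of the two numbers, 10400 nM. The next change is 4-methoxyphenyl in place of 3-methoxyphenyl on an aromatic nitrogen. Among the measured compounds shown here, only one measured step bears on this, a 26-fold higher number from compound 1 to compound 2 (1.41 log units; beyond the scatter), a large step beyond the scatter, with 3-methoxyphenyl in place of 4-methylphenyl at that same place. Two compounds establish no rule. Even so, compound 3 returns to a 4-substituted phenyl, as in compound 1 at 400 nM, so most of that step is expected to be recovered. The expected step is a 15-fold lower number from compound 2 to compound 3 (1.17 log units; beyond the scatter), a large one toward a lower number in this assay. For compound 3 the estimate is 700 nM, with an expected range of 120 nM to 4000 nM.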

Compound 3, half-maximal inhibitory concentration: 500 nM
The estimate for compound 3 lay 1.4-fold (0.15 log units) above the measured number; the range from low to high includes it.
By their numbers in this assay, from the lowest: compounds 1 and 3 (each within the scatter of the next); then compound 2.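

In this assay, 4-methoxyphenyl in place of 3-methoxyphenyl on the aromatic nitrogen gives a 21-fold lower number from compound 2 to compound 3 (1.32 log units; beyond the scatter); since the two compounds have the same atoms, the arrangement of the methoxy group on the phenyl alone separates them. Methoxy in place of methyl on an aromatic carbon gives a 1.3-fold higher number from compound 1 to compound 3 (0.10 log units; within the scatter), within the scatter, so this assay does not distinguish 4-methylphenyl from 4-methoxyphenyl, and the large step from compound 1 to compound 2 now appears to follow the placement of the substituent more than its identity. No available data explain the difference between 3-methoxyphenyl and 4-methoxyphenyl.

From the compounds shown here alone, it remains open whether 3-methylphenyl would track 3-methoxyphenyl, which would test that reading directly. Also open, going by these compounds, is whether an amine, a carboxylic acid or a longer chain such as ethoxy would be accommodated in place of the methoxy of 4-methoxyphenyl.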